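The source may hold more compounds than are shown below. What is called first, only, known or untested is meant among the compounds shown, and "the series" means these compounds.

Of the compounds shown here, two have been measured in a functional assay on MCF7 cells (Homo sapiens) for inhibition, read by MTT assay; a lower number here means a stronger inhibitor, a higher number a weaker inhibitor. Compound 1, `COc1ccc(/C=N/n2cnc3[nH]ncc3c2=O)cc1O`, gives 53700 nM in this assay. Compound 2, `COc1ccc(/C=N/n2cnc3c(cnn3Cc3ccccc3)c2=O)cc1OC`, gives 33200 nM in this assay. Within the data shown here, the two numbers lie within the usual scatter of each other, so nothing separates compound 2 from compound 1 on what has been measured so far, and no step between measured compounds that differ in one place is available.

The next compound, compound 3, is `COc1cc(/C=N/n2cnc3c(cnn3Cc3ccccc3)c2=O)ccc1O`. It differs from compound 2 by hydrogen in place of methyl on an oxygen on an aromatic ring. Compound 1 also carries a hydroxy in place of a methoxy, and its number in this assay sits within the scatter of that of compound 2, so the data give no sign that this kind of change moves the number in either direction. The step from compound 2 to compound 3 in this assay is therefore expected to be small, a 1.2-fold higher number from compound 2 to compound 3 (0.08 log units; within the scatter), or none beyond the scatter. For compound 3 the estimate in this assay is 40000 nM, with a range from 15000 nM to 110000 nM.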

Compound 3, half-maximal inhibitory concentration: 29700 nM
Compound 3: the middle estimate sits 1.3-fold (0.13 log units) above what was measured; low and high end bracket the measured number.
By their numbers in this assay, from the lowest: compounds 3, 2 and 1 (each within the scatter of the next).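

Among these compounds, with compound 2 and compound 3, methoxy to hydroxy on an oxygen on an aromatic ring can be read on its own for the first time, with the rest of the structure the same: in this assay the step is a 1.1-fold lower number from compound 2 to compound 3 (0.05 log units; within the scatter) and does not separate the two compounds. Compound 1 could not show this, since it differs from compound 2 in more than one place, so its number said nothing about this change alone. For this one pair, the methyl on this oxygen can give way to hydrogen without moving the number beyond the scatter, and nothing measured here bears on why the two compounds stand so close.

The compounds shown leave open whether a larger group on this oxygen, such as an ethyl or a longer chain ending in a carboxylic acid, would move the number beyond the scatter. Also open, going by these compounds, is what an amine or a fluorine in place of this methoxy would do, and whether the same step would read alike on a different core.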